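Moving the Oxygen Within a Five-Membered Ring

The source may report more compounds than this note shows. Statements on the series, on what has been measured and on what is new or still open speak of the compounds shown alone.

Compound 2 `Cc1cc(C)c(CN2CCc3c(Cl)cc([C@H](CO)[C@@H]4CCCO4)c(Cl)c3C2=O)c(=O)[nH]1` stands highest of the two numbers measured in an ADME assay on microsomes from liver (Homo sapiens) for metabolic stability, read by LC-MS, using NADPH, with stated times of 10 min and 45 min, tested at 1 uM (on this read-out higher numbers stand for fast clearance and lower numbers for slow clearance), giving 37.6 uL/min. Among the compounds with values here, compound 1 `Cc1cc(C)c(CN2CCc3c(Cl)cc([C@@H](C)CO)c(Cl)c3C2=O)c(=O)[nH]1` gives 12.4 uL/min in this assay, and the only measured step, a 3.0-fold higher number from compound 1 to compound 2 (0.48 log units; beyond the scatter), shows what the oxolan-2-yl ring brought when it replaced methyl. Compound 3 `Cc1cc(C)c(CN2CCc3c(Cl)cc([C@H](CO)[C@H]4CCOC4)c(Cl)c3C2=O)c(=O)[nH]1` differs from compound 2 by oxolan-3-yl in place of oxolan-2-yl on a saturated chain carbon bound to an aromatic carbon and a saturated chain carbon. Within the data shown here, no measured step covers a change of this sort, where the two structures hold the same atoms joined differently; the step from compound 1 to compound 2 bears only loosely, showing that the ring itself, not its point of attachment, set the higher number. A step is therefore expected for compound 3 of a 1.2-fold lower number from compound 2 to compound 3 (0.07 log units; within the scatter), which is no change beyond the scatter. The estimate for compound 3 in this assay is 32 uL/min, with a range from 16 uL/min to 64 uL/min.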

Compound 3, intrinsic clearance in a liver preparation (reported as CLH), per the amount of preparation that the assay uses in the liver assay: 21.3 uL/min
The estimate for compound 3 lay 1.5-fold (0.18 log units) above the measured number; the measured number falls inside the stated range.
By their numbers in the liver assay, from the lowest: compounds 1, 3 and 2 (each within the scatter of the next, the first and the last beyond it).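

In the liver assay, moving the ring attachment from oxolan-2-yl to oxolan-3-yl gives a 1.8-fold lower number from compound 2 to compound 3 (0.25 log units; within the scatter) and so stays inside the normal spread of repeat measurements, while replacing methyl with oxolan-3-yl gives a 1.7-fold higher number from compound 1 to compound 3 (0.23 log units; within the scatter) and also stays inside it. This differs from the oxolan-2-yl ring, whose step from methyl was beyond the scatter, although the data cannot separate the two rings from each other. In a physicochemical assay for solubility, measured as kinetic solubility (on this read-out lower numbers stand for lower solubility and higher numbers for higher solubility), compound 2 gives 400000 nM and compound 3 gives 570000 nM, and a 1.4-fold higher number from compound 2 to compound 3 (0.15 log units; within the scatter) again shows no change beyond the scatter. From the compounds shown here alone, whether an amine or a carboxylic acid at this place would follow oxolan-2-yl or oxolan-3-yl remains open. Nothing given here offers a reason for these numbers.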